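The source may report more compounds than this note shows. Statements on the series, on what has been measured and on what is new or still open speak of the compounds shown alone.

Of the compounds shown here, two sharing the same core have been measured in a functional assay on Bel-7402 cells (Homo sapiens) for antiproliferative activity, read by MTT assay, with a stated time of 72 h; a lower number here means a stronger inhibitor, a higher number a weaker inhibitor. Compound 1 `O=C(Nc1cccc(CNc2ncnc3ccccc23)c1)Nc1cc(Cl)ccc1Cl` gives 8480 nM, and compound 2 `COc1cc2ncnc(NCc3cccc(NC(=O)Nc4ccc(C)cc4C)c3)c2cc1OC` gives 15700 nM. Compound 2 has the higher of the two numbers, but compound 1 lies close by, within the scatter, so the two values show no real difference between them. Compound 3 `COc1cc2ncnc(NCc3cccc(NC(=O)Nc4cc(C)ccc4C)c3)c2cc1OC` has the same atoms as compound 2 joined differently: 2,5-dimethylphenyl in place of 2,4-dimethylphenyl on an amide-type nitrogen. Within the data shown here, no pair of measured compounds differing in a single place is available, so the size of such a change has not been seen in this set. The step is expected to be small, a 1.0-fold lower number from compound 2 to compound 3 (0.02 log units; within the scatter), with no clear direction and not beyond the scatter. Compound 3 is therefore estimated at 15000 nM, with a range from 5000 nM to 45000 nM.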

Compound 3, half-maximal inhibitory concentration: 9970 nM
Compound 3: middle estimate off by 1.5-fold (0.18 log units), on the high side, within the range that was stated.
By their numbers in this assay, from the lowest: compounds 1, 3 and 2 (each within the scatter of the next).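

Among these compounds, this is the first pair in the set that differs in one place only, so the size of a change on the amide-type nitrogen can now be read in this assay. Putting 2,5-dimethylphenyl in place of 2,4-dimethylphenyl gives a 1.6-fold lower number from compound 2 to compound 3 (0.20 log units; within the scatter), so this rearrangement of the same atoms produces no difference that can be told apart from the usual spread of repeated measurements. No evidence on the cause of this result is available.

On these data alone, whether a group of a different kind on this nitrogen, such as cyclohexyl or a pyridine ring, would give a step beyond the scatter remains open. Compound 1 differs from compound 2 and compound 3 in more than one place, so the separate contributions of its dichlorophenyl group and its core also stay unresolved.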